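This account rests on a few compounds, and the source may have more. Where it says the series, first, only, none or still open, it means among the compounds named here.

Working notes on the series in an ADME assay on Vero cells (Chlorocebus sabaeus) for cytotoxicity, with a stated time of 7 days; a higher number here means that more compound is tolerated, a lower number that less compound is tolerated. Compound 1 `COc1ccc2[nH]c(C(=O)N3CC(=O)N(Cc4ccccc4)[C@@H](CN4CCC5(CC4)CC5)C3)cc2c1` gives 17100 nM. Compound 2 `COc1ccc2[nH]c(C(=O)N3CC(=O)N(Cc4ccccc4)[C@@H](COCc4ccccc4)C3)cc2c1` returns only a limit, > 30000 nM. Compound 3 `COc1ccc2[nH]c(C(=O)N3CC(=O)N(Cc4ccccc4)[C@@H](CN4C(=O)c5ccccc5C4=O)C3)cc2c1` gives 41000 nM, the higher of the two actual numbers in hand.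

The next change leads to compound 4 `COc1ccc2[nH]c(C(=O)N3CC(=O)N(Cc4ccccc4)[C@@H](CN4CC5CCCCC5C4)C3)cc2c1`: a group of 9 heavy atoms (8 carbon, 1 nitrogen; one five-membered non-aromatic ring with 1 hetero atom, one six-membered non-aromatic ring of carbon only) in place of a group of 11 heavy atoms (8 carbon, 1 nitrogen, 2 oxygen; one five-membered non-aromatic ring with 1 hetero atom, one six-membered aromatic ring of carbon only), on a saturated chain carbon bound to a saturated ring carbon. The one-ring-with-hetero-atom part stays five-membered, while the six-membered aromatic ring of carbon only gives way to a six-membered non-aromatic ring of carbon only, and the 2 double bonds outside aromatic rings go.

Compound 1 also carries a non-aromatic group with 1 hetero atom at this place, so the most relevant measurement is a 2.4-fold higher number from compound 1 to compound 3 (0.38 log units; beyond the scatter), read in reverse. The step of an at least 1.7-fold higher number from compound 1 to compound 2 (0.24 log units; that floor lies within the scatter) gives only a floor and adds little. A modest fall to a number near that of compound 1 is therefore expected.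

The expected change is a 2.4-fold lower number from compound 3 to compound 4 (0.38 log units; beyond the scatter).

For compound 4 the estimate is 17000 nM, with an expected range of 8000 nM to 36000 nM.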

Compound 4, half-maximal cytotoxic concentration: 8200 nM
Beside the measured number, compound 4's estimate is 2.1-fold (0.32 log units) above it, within the range that was stated.
By their numbers in this assay, from the lowest: compound 4; then compound 1; then compound 3.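

In this assay, within the data shown here, the group with a six-membered non-aromatic ring of carbon only gives the lowest number so far at this saturated chain carbon, with a 5.0-fold lower number from compound 3 to compound 4 (0.70 log units; beyond the scatter), a 2.1-fold lower number from compound 1 to compound 4 (0.32 log units; beyond the scatter) and an at least 3.6-fold lower number from compound 2 to compound 4 (0.56 log units; beyond the scatter). Compound 1 and compound 4, the two compounds without an aromatic ring in this group, now hold the two lowest numbers, and no compound shown goes against this. Compound 2 is known only as a limit, so its step gives only a floor: the limit of > 30000 nM in this assay, at which 1 of the 4 values shown sits.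

The aromatic ring and the 2 double bonds outside aromatic rings leave together in the change to compound 4, so their separate contributions remain unresolved. Going by these compounds, how an open-chain amine or a carboxylic acid on this carbon would read in this assay also remains open.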